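A few compounds are considered here, and "the series" means these few. Any claim that something is new, unique, unknown or untested is made for them only; others in the source may bear on it.

Compound 1 `COc1cc(-c2nn(-c3cccc(NC(=O)c4cccc(C(F)(F)F)c4)c3)cc2-c2ccncc2)ccc1Cl` is the amide of the pair. In a functional assay on UACC-257 cells (Homo sapiens) for inhibition, read by sulforhodamine B assay, with a stated time of 48 h (a lower number here means a stronger inhibitor of growth, a higher number a weaker inhibitor of growth), compound 1 gives only a limit, > 50000 nM, which is the limit of > 50000 nM in this assay, at which 1 of the 2 values shown sits. Compound 2 `O=C(Nc1cccc(-n2cc(-c3ccncc3)c(-c3ccc(Cl)c(O)c3)n2)c1)Nc1cc(C(F)(F)F)cc(C(F)(F)F)c1` differs from compound 1 in more than one place but carries a carbamoyl linkage; in this assay compound 2 gives 2550 nM. Compound 3 `COc1cc(-c2nn(-c3cccc(NC(=O)Nc4ccc(Cl)c(Cl)c4)c3)cc2-c2ccncc2)ccc1Cl` is not yet measured; it differs from compound 1 by (3,4-dichlorophenyl)amino in place of 3-(trifluoromethyl)phenyl on a carbonyl carbon. Given that compound 2 gives 2550 nM in this assay, the expected step of an at least 8.3-fold lower number from compound 1 to compound 3 (0.92 log units; beyond the scatter) is beyond the scatter, toward stronger growth inhibition. For compound 3 the estimate is 6000 nM, within 1500 nM to 30000 nM.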

Compound 3, concentration for total growth inhibition: 3110 nM
For compound 3 the middle estimate is 1.9-fold (0.29 log units) above the measured one, within the range that was stated.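

In this assay, among these compounds, (3,4-dichlorophenyl)amino in place of 3-(trifluoromethyl)phenyl on the carbonyl carbon gives the only single-place comparison: an at least 16-fold lower number from compound 1 to compound 3 (1.20 log units; beyond the scatter). This change alone, on the core of compound 1, moves the read-out from a limit to a measured value. The full size of the step remains unknown, as compound 1 reads only as a limit: the limit of > 50000 nM in this assay, at which 1 of the 3 values shown sits.

The amino nitrogen and the ring substituents change together here, so their contributions cannot be separated. A (3-(trifluoromethyl)phenyl)amino group or a 3,4-dichlorophenyl group on the same carbonyl carbon would separate them.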